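The source may hold more compounds than are shown below. What is called first, only, known or untested is meant among the compounds shown, and "the series" means these compounds.

In a functional assay on MCF7 cells (Homo sapiens) for antiproliferative activity, read by MTT assay, with a stated time of 72 h (a lower number here means a stronger inhibitor, a higher number a weaker inhibitor), compound 1 `Nc1nc(N)c2cc(CSC(=S)N3CCN(c4ccccc4)CC3)ccc2n1` gives 2950 nM, compound 2 `Cc1ccc(N2CCN(C(=S)SCc3ccc4nc(N)nc(N)c4c3)CC2)cc1` gives 2480 nM and compound 3 `CC(=O)c1ccc(N2CCN(C(=S)SCc3ccc4nc(N)nc(N)c4c3)CC2)cc1` gives 2490 nM, so compound 3 cannot be told apart from the other two. The next structure is compound 4 `Nc1nc(N)c2cc(CSC(=S)N3CCN(c4ccccc4[N+](=O)[O-])CC3)ccc2n1`, with this change: 2-nitrophenyl in place of 4-acetylphenyl on an amine nitrogen in a ring. In short, 2-nitrophenyl replaces 4-acetylphenyl on an amine nitrogen in a ring. The measured steps that bear on it all concern substitution on that aromatic ring: a 1.2-fold lower number from compound 1 to compound 2 (0.08 log units; within the scatter), a 1.2-fold lower number from compound 1 to compound 3 (0.07 log units; within the scatter) and a 1.0-fold higher number from compound 2 to compound 3 (0.00 log units; within the scatter). Going by the values given here, no measured compound carries 2-nitrophenyl, so this is an extrapolation. In this assay, no step beyond the scatter is expected, and the expected step is a 1.0-fold higher number from compound 3 to compound 4 (0.02 log units; within the scatter). The estimate for compound 4 is 2600 nM, within an expected range of 1300 nM to 5200 nM.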

Compound 4, half-maximal inhibitory concentration: 4350 nM
Beside the measured number, compound 4's estimate is 1.7-fold (0.22 log units) below it, and the stated range covers the measured number.
By their numbers in this assay, from the lowest: compounds 2, 3, 1 and 4 (each within the scatter of the next).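

In this assay, 2-nitrophenyl on the amine nitrogen in the ring stays within the scatter of all three earlier aryl groups, against phenyl (a 1.5-fold higher number from compound 1 to compound 4 (0.17 log units; within the scatter)), 4-methylphenyl (a 1.8-fold higher number from compound 2 to compound 4 (0.24 log units; within the scatter)) and 4-acetylphenyl (a 1.7-fold higher number from compound 3 to compound 4 (0.24 log units; within the scatter)). This position therefore also accepts a nitro group, and a substituent named at the 2 position rather than the 4 position, without a step beyond the scatter. No available evidence explains these steps. Going by these compounds, it remains open whether an amine or a carboxylic acid on this aromatic ring would give a step beyond the scatter.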